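The compounds below may be only part of what the source reports. "The series", "measured", "known", "first", "only" and "open" are said of these compounds alone.

Of the compounds shown here, three of the shared core have been measured in a functional assay on PC-3 cells (Homo sapiens) for inhibition, read by MTT assay, with a stated time of 72 h; a higher number here means a weaker inhibitor, a lower number a stronger inhibitor. Compound 1 `C#CCSc1nc(Nc2ccccc2)c2ccncc2n1` gives only a limit of the assay, > 80000 nM. Compound 3 `C#CCSc1nc(Nc2cccc(O)c2)c2ccncc2n1` likewise gives only a limit, > 80000 nM. Within the data shown here, compound 2 `C#CCSc1nc(Nc2cccc(OC)c2)c2ccncc2n1` is the one compound with a number, 17100 nM, and so is the single point of reference here.

Compound 4 `COc1cccc(Nc2nc(SCC3CC3)nc3cnccc23)c1` differs from compound 2 in one place: cyclopropyl in place of ethynyl on a saturated chain carbon bound to a sulfur. Neither measured step touches that part of the molecule. The step of an at least 4.6-fold lower number from compound 1 to compound 2 (0.67 log units; beyond the scatter) and the step of an at least 4.6-fold higher number from compound 2 to compound 3 (0.67 log units; beyond the scatter) both concern the substituent on the aromatic ring, while the change from compound 2 to compound 4 sits on the sulfanyl chain, so nothing measured bears directly on it. For that reason the expected step of a 1.0-fold lower number from compound 2 to compound 4 (0.00 log units; within the scatter) is not beyond the scatter. Compound 4 is therefore estimated at 17000 nM in this assay, with a range from 6000 nM to 50000 nM.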

Compound 4, half-maximal inhibitory concentration: 14800 nM
Estimate against measurement, compound 4: 1.1-fold (0.06 log units) above; the measured number falls inside the stated range.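

In this assay, putting cyclopropyl in place of ethynyl on a saturated chain carbon bound to a sulfur gives a 1.2-fold lower number from compound 2 to compound 4 (0.06 log units; within the scatter). Among these compounds, this is the first measured change at this place, since the earlier steps all concerned the substituent on the aromatic ring, and it shows that losing the triple bond and gaining a three-membered ring of carbon only does not move the read-out beyond the scatter. Compound 2 is no longer the only compound with a number, as compound 4 now stands with it, while the two compounds without the methoxy group remain at a limit: the limit of > 80000 nM in this assay, at which 2 of the 4 values shown sit.

From the compounds shown here alone, what a longer chain, an amine or a carboxylic acid on the sulfanyl chain would do here stays open. Going by these compounds, it is also open whether cyclopropylmethyl would give the same picture with hydroxy in place of methoxy on the aromatic ring.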